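The source may report more compounds than this note shows. Statements on the series, on what has been measured and on what is new or still open speak of the compounds shown alone.

In a functional assay on ACHN cells (Homo sapiens) for antiproliferative activity, read by sulforhodamine B assay (a lower number here means a stronger inhibitor of growth, a higher number a weaker inhibitor of growth), three compounds have been measured:

Compound 1 `CC1CC(=O)c2s/c(=N/c3ccccc3)oc2C1` gives 2980 nM.
Compound 2 `CC(C)C1CC(=O)c2s/c(=N/c3ccccc3)oc2C1` gives 3080 nM.
Compound 3 `CC1CC(=O)c2s/c(=N/c3c(Cl)cc(Cl)cc3Cl)oc2C1` gives > 30000 nM, which is a limit of the assay rather than a number.

From compound 1 to compound 2 the change is isopropyl in place of methyl on a saturated ring carbon, and the step is a 1.0-fold higher number from compound 1 to compound 2 (0.01 log units; within the scatter). Compound 4 `CC(C)C1CC(=O)c2s/c(=N/c3c(Cl)cc(Cl)cc3Cl)oc2C1` has not yet been measured; it differs from compound 3 by isopropyl in place of methyl on a saturated ring carbon, the same change made at the same place. The difference between the cores of compound 1 and compound 3 is not broken down here. With compound 3 sitting at the limit of > 30000 nM in this assay, at which 1 of the 3 values shown sits, and the step of a 1.0-fold higher number from compound 1 to compound 2 (0.01 log units; within the scatter) within the scatter, the expected step for compound 4 is a step that the limit leaves unreadable from compound 3 to compound 4, most likely again only a limit. Compound 4 is therefore estimated at 40000 nM, with a range from 15000 nM to 100000 nM.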

Compound 4, concentration for 50% growth inhibition: > 30000 nM
Compound 4 ended at the assay's limit; the forecaster's own chance of this, stated with the estimate: 80%; the middle value is on the limit's open side.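

For the compounds shown here, compound 3 and compound 4 both end at a limit rather than a number, so no step between them can be read: the limit of > 30000 nM in this assay, at which 2 of the 4 values shown sit. The compounds shown leave open whether isopropyl in place of methyl changes anything on the core of compound 3.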